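The source may report more compounds than this note shows. Statements on the series, on what has been measured and on what is new or still open speak of the compounds shown alone.

Compound 1, `CC(C)n1cc(OC(=O)C(C)(C)C)nc1N/C(=N\C(=O)C(C)(C)C)Nc1ccc(Cl)c(Cl)c1`: > 1 h
Compound 2, `CC(C)(C)N1CC(=O)N=C1NC(=N)Nc1ccc(Cl)c(Cl)c1`: > 1 h

In an in vivo ADME assay on the whole organism for metabolic stability, with Mus musculus as the target, read by LC-MS, at a dose of 160 mg/kg by the oral route (a higher number here means that the compound lasts longer, a lower number that the compound disappears faster), compound 1 returns only a limit of the assay, > 1 h. Compound 2 also returns only a limit of the assay, > 1 h. Compound 2 thus stands where every measured value sits, at the limit of > 1 h in this assay, at which 2 of the 2 values shown sit. Compound 3, `CN1CC(=O)N=C1NC(=N)Nc1ccc(Cl)c(Cl)c1`, is not yet measured in this assay. It differs from compound 2 by methyl in place of tert-butyl on an amine nitrogen in a ring. Going by the values given here, no measured pair carries this kind of change, so the expected step, a step that the limit leaves unreadable from compound 2 to compound 3, is none beyond the usual scatter. Compound 3 is therefore estimated at 1.5 h, within a range from 0.5 h to 4 h.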

Compound 3, half-life: > 1 h
Compound 3: only a limit was reported; the forecaster's own chance of this, stated with the estimate: 50%; the middle value does not contradict the limit.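

No step can be read from compound 2 to compound 3 in this assay, since each gives only a limit and not a number. The compounds shown leave open how long each actually lasts, and whether methyl in place of tert-butyl changes that.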